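The source may hold more compounds than are shown below. What is called first, only, known or untested is meant among the compounds shown, and "the series" means these compounds.

Three compounds share one core and differ only in the group carried on the amine nitrogen. Compound 1 `CCc1ccc(NC2=CC(=O)c3c(nc4n3[C@H]3OC[C@@H](O)[C@H]3OC4)C2=O)cc1` gives 6510 nM in a functional assay on HeLa cells (Homo sapiens) for inhibition, read by sulforhodamine B assay (on this read-out higher numbers stand for weaker inhibition and lower numbers for stronger inhibition), the highest of the three numbers. Compound 2 `O=C1C=C(Nc2ccc(Br)cc2)C(=O)c2c1nc1n2[C@H]2OC[C@@H](O)[C@H]2OC1` gives 3830 nM in this assay, which lies within the scatter of compound 1. Compound 3 `Cc1ccc(NC2=CC(=O)c3nc4n(c3C2=O)[C@H]2OC[C@@H](O)[C@H]2OC4)cc1C` gives 2690 nM in this assay, beyond the scatter from compound 1. For the measured compounds named here, the only measured step, a 1.4-fold lower number from compound 2 to compound 3 (0.15 log units; within the scatter), exchanges one six-membered aromatic ring of carbon only for another and stays within the scatter.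

Compound 4 `O=C1C(NC2CC2)=CC(=O)c2c1nc1n2[C@H]2OC[C@@H](O)[C@H]2OC1` has not yet been measured in this assay. It differs from compound 1 as follows: cyclopropyl in place of 4-ethylphenyl on an amine nitrogen. Going by the values given here, no measured step bears on this change: the single step available keeps a six-membered aromatic ring of carbon only in place, whereas here that ring leaves and a three-membered non-aromatic ring of carbon only enters. The data therefore give no direction, and the expected step is a 1.2-fold higher number from compound 1 to compound 4 (0.09 log units; within the scatter), with wide uncertainty. In this assay compound 4 is estimated at 8000 nM, with a range from 2000 nM to 40000 nM.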

Compound 4, half-maximal inhibitory concentration: > 16000 nM
Compound 4 ended at the assay's limit; the forecaster's own chance of this, stated with the estimate: 15%; middle value at least 2.0-fold (0.30 log units) away from the limit.
By their numbers in this assay, from the lowest: compounds 3, 2 and 1 (each within the scatter of the next, the first and the last beyond it). At a limit, above all of these: compound 4.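

For compound 4 the reading in this assay is a limit of the assay and not a number: the limit of > 16000 nM in this assay, at which 1 of the 4 values shown sits.

For the compounds shown here, exchanging 4-ethylphenyl for cyclopropyl on the amine nitrogen gives an at least 2.4-fold higher number from compound 1 to compound 4 (0.39 log units; beyond the scatter), the first step at this position that lies beyond the scatter, and its true size remains unread past that limit. The earlier step only exchanged one six-membered aromatic ring of carbon for another, whereas this one removes that ring and shows that the number at this position does respond to the group on the amine nitrogen.

The compounds shown do not separate the departure of the aromatic ring from the drop in heavy atoms, which a cyclohexyl group on the same nitrogen could address. They also leave open how a longer alkyl chain or a benzyl group would read there.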